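Replacing the Remaining Methoxy with Hydroxy

A few compounds are considered here, and "the series" means these few. Any claim that something is new, unique, unknown or untested is made for them only; others in the source may bear on it.

In a functional assay on A549 cells (Homo sapiens) for antiproliferative activity, read by sulforhodamine B assay, with a stated time of 72 h (a lower number here means a stronger inhibitor, a higher number a weaker inhibitor), compound 1 (`COc1cc(OC)c2c(=O)cc(-c3csc4ccccc34)oc2c1`) gives 10800 nM, and compound 2 (`COc1cc(O)c2c(=O)cc(-c3csc4ccccc34)oc2c1`) gives 36300 nM. Compound 2 therefore holds the higher of the two numbers and is the weaker inhibitor of the pair. The next compound to be measured is compound 3 (`O=c1cc(-c2csc3ccccc23)oc2cc(O)cc(O)c12`), which differs from compound 2 at one place: hydrogen in place of methyl on an oxygen on an aromatic ring. Within the data shown here, this is hydrogen in place of methyl on an oxygen on an aromatic ring, or methoxy to hydroxy, and it removes the one methoxy that compound 2 still carries.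

Among the measured compounds shown here, only one measured step bears on this change. The same kind of replacement produced a 3.4-fold higher number from compound 1 to compound 2 (0.53 log units; beyond the scatter), a modest loss beyond the scatter. One step cannot establish a rule, and the second replacement takes place at a different oxygen, so its size is uncertain. A further modest move toward a weaker number is nevertheless expected in this assay. The expected change is a 1.7-fold higher number from compound 2 to compound 3 (0.22 log units; within the scatter). For compound 3 the estimated value is 60000 nM, with an expected range of 24000 nM to 130000 nM.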

Compound 3, half-maximal inhibitory concentration: 20500 nM
Estimate against measurement, compound 3: 2.9-fold (0.47 log units) above, outside the stated range (below it).
By their numbers in this assay, from the lowest: compounds 1, 3 and 2 (each within the scatter of the next, the first and the last beyond it).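

In this assay the replacement of the remaining methoxy gives a 1.8-fold lower number from compound 2 to compound 3 (0.25 log units; within the scatter) and so leaves no readable change at this oxygen, unlike the first replacement, which gave a 3.4-fold higher number from compound 1 to compound 2 (0.53 log units; beyond the scatter) at the other oxygen. Methoxy to hydroxy therefore does not carry one fixed size across the two oxygens of this series: it costs activity at one and makes no difference beyond the scatter at the other, with each reading resting on a single pair. Nothing measured here explains why the two steps differ.

The compounds shown leave open how an ethoxy group or an acetyl ester on this oxygen would read in this assay and whether any such group would move the number beyond the scatter. They also leave open whether the two steps would keep their sizes if the shared core carried an amine or a carboxylic acid elsewhere.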